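The source may report more compounds than this note shows. Statements on the series, on what has been measured and on what is new or still open speak of the compounds shown alone.

Measured so far in a functional assay on A2780 cells (Homo sapiens) for inhibition, read by sulforhodamine B assay, with a stated time of 72 h; on this read-out lower numbers stand for stronger inhibition and higher numbers for weaker inhibition:
- compound 1 `O=C(NCc1ccc(S(=O)(=O)N2CCCCC2)cc1)c1cc2cnccc2o1`: 1500 nM
- compound 2 `O=C(NCc1ccc(S(=O)(=O)c2ccccc2)cc1)c1cc(-c2cccnc2)no1`: > 10000 nM (a limit of the assay)
- compound 3 `O=C(NCc1ccc(S(=O)(=O)c2ccccc2)cc1)c1ccc2nncn2c1`: > 10000 nM (a limit of the assay)

Within the data shown here, compound 1 is the only compound with an actual number, 1500 nM. The remainder of the set reads only as the limit of > 10000 nM in this assay, at which 2 of the 3 values shown sit. Compound 2 and compound 3 differ from compound 1 in more than one place, so they give no size for a single change.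

Compound 4 `O=C(NCc1ccc(S(=O)(=O)N2CCCCC2)cc1)c1ccn2cncc2c1` keeps the rest of compound 1 and alters only the group on the carbonyl carbon: a group of 9 heavy atoms (7 carbon, 2 nitrogen; one five-membered aromatic ring with 2 hetero atoms, one six-membered aromatic ring with 1 hetero atom) in place of a group of 9 heavy atoms (7 carbon, 1 nitrogen, 1 oxygen; one five-membered aromatic ring with 1 hetero atom, one six-membered aromatic ring with 1 hetero atom), on a carbonyl carbon. Among the measured compounds shown here, no measured pair covers a swap of this kind. With compound 1 at 1500 nM as the sole anchor, no shift beyond the usual scatter is expected in this assay, in either direction, though the uncertainty is wide. The estimated step is a 1.5-fold lower number from compound 1 to compound 4 (0.18 log units; within the scatter). Compound 4 is expected at 1000 nM, with an estimated range of 150 nM to 7000 nM.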

Compound 4, half-maximal inhibitory concentration: > 10000 nM
Compound 4: no number, only a limit; the forecaster's own chance of this, stated with the estimate: 10%; middle value at least 10-fold (1.00 log units) away from the limit.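

In this assay, among these compounds, the swap on the carbonyl carbon gives an at least 6.6-fold higher number from compound 1 to compound 4 (0.82 log units; beyond the scatter), the first change in a single place that can be read. The group that enters matches the group that leaves in heavy atoms, donors and acceptors, yet the result shows that this position does not accept every group of that size. The value of compound 4, > 10000 nM, is a limit of the assay, so the step has a lower end only: the limit of > 10000 nM in this assay, at which 3 of the 4 values shown sit.

How far compound 4 lies past that limit stays unknown, and this single pair gives no reason for the loss. On these data alone, whether an amine or a carboxylic acid on the group at the carbonyl carbon would give a measurable number in this assay also stays open.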